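A few compounds are considered here, and "the series" means these few. Any claim that something is new, unique, unknown or untested is made for them only; others in the source may bear on it.

Going by the values given here, compound 3, `Cc1oc(-c2c(Cl)cccc2C(F)(F)F)nc1CN1CCC(C(=O)NCCCN2C[C@H](C)C[C@H](C)C2)CC1`, is one of three compounds measured in an ADME assay on microsomes from liver (Rattus norvegicus) for metabolic stability, read by LC-MS, using NADPH, at 37 degrees C; on this read-out higher numbers stand for a longer-lived compound and lower numbers for a shorter-lived compound. In this assay compound 3 gives 0.03 h. Compound 1, `Cc1cccc(Cl)c1-c1nc(CN2CCC(C(=O)NCCCN3CCC(C(C)C)CC3)CC2)c(C)o1`, gives 0.0333 h in this assay, a number within the usual scatter of that of compound 3, so the two cannot be told apart. Compound 2, `Cc1ccccc1-c1nc(CN2CCC(C(=O)N3CCN(C4CCN(C)CC4)CC3)CC2)c(C)o1`, returns only a limit of this assay, > 0.5 h, and not a number. That limit is the limit of > 0.5 h in this assay, at which 1 of the 3 values shown sits.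

The next compound in the line is compound 4, `COc1cccc(OC)c1-c1nc(CN2CCC(C(=O)NCCCN3C[C@H](C)C[C@H](C)C3)CC2)c(C)o1`, which is not yet measured in this assay. It differs from compound 3 in one place: 2,6-dimethoxyphenyl in place of 2-chloro-6-(trifluoromethyl)phenyl on an aromatic carbon. Among the compounds with values here, no pair of measured compounds differs in just one place, so there is no measured step to lean on, and the single change gives no direction on its own. The account therefore expects no step beyond the scatter from compound 3 to compound 4, with the estimated step of no change at the digits printed from compound 3 to compound 4 (within the scatter). For compound 4 the expected half-life in this assay is 0.03 h, in a range from 0.012 h to 0.08 h.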

Compound 4, half-life: 0.2 h
Estimate against measurement, compound 4: 6.7-fold (0.82 log units) below; measured number above the stated range.
By their numbers in this assay, from the lowest: compounds 3 and 1 (each within the scatter of the next); then compound 4. At a limit, above all of these: compound 2.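

In this assay the aromatic carbon next to the ring nitrogen and next to the ring oxygen proves to be a place where the aryl group matters: 2,6-dimethoxyphenyl in place of 2-chloro-6-(trifluoromethyl)phenyl gives a 6.7-fold higher number from compound 3 to compound 4 (0.82 log units; beyond the scatter), with the rest of the molecule unchanged. The earlier compounds shown here differ from one another in more than one place, and none of them could show what this aryl group does on its own. Nothing measured in the compounds shown gives a reason for this step.

On these data alone, it remains open whether the step needs both methoxy groups or follows from the loss of the chlorine or of the trifluoromethyl alone. As far as these compounds go, a phenyl ring carrying a single methoxy, a fluorine or a nitrile would separate these readings, and it is also open whether the step holds with other amide side chains.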